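The source may hold more compounds than are shown below. What is called first, only, known or untested is meant among the compounds shown, and "the series" means these compounds.

Measured compounds:
- compound 1, `CCN(CC)c1ccc(/C=C2/SC(Nc3ccccc3)=NC2=O)cc1`: 0.1 ug/mL
- compound 2, `CN1CCN(c2ccc(/C=C3/SC(Nc4ccccc4)=NC3=O)cc2)CC1`: 0.35 ug/mL
- compound 3, `CCN(CC)c1ccc(/C=C2/SC(N(c3ccccc3)c3ccccc3)=NC2=O)cc1`: 0.01 ug/mL

Of the compounds shown here, three built on one shared core have been tested in a physicochemical assay (Homo sapiens) for solubility, with a stated time of 18 h, at pH 7.4; on this read-out lower numbers stand for lower solubility and higher numbers for higher solubility. In this assay compound 1 gives 0.1 ug/mL, compound 2 gives 0.35 ug/mL, and compound 3 gives 0.01 ug/mL, the lowest of the three numbers.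

Two single changes link these compounds. The first is 4-methylpiperazin-1-yl in place of diethylamino on an aromatic carbon, and it gave a 3.5-fold higher number from compound 1 to compound 2 (0.54 log units; beyond the scatter). The second is phenyl in place of hydrogen on a nitrogen on an aromatic ring, and it gave a 10-fold lower number from compound 1 to compound 3 (1.00 log units; beyond the scatter).

Compound 4, `CN1CCN(c2ccc(/C=C3/SC(N(c4ccccc4)c4ccccc4)=NC3=O)cc2)CC1`, has not yet been measured in this assay. It relates to compound 3 exactly as compound 2 relates to compound 1: the change is 4-methylpiperazin-1-yl in place of diethylamino on an aromatic carbon, at the same place, so it is the same change. The core of compound 3 and compound 4 differs from that of compound 1 and compound 2 by phenyl in place of hydrogen on a nitrogen on an aromatic ring.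

For the measured compounds named here, the only guide to compound 4 is the earlier step, a 3.5-fold higher number from compound 1 to compound 2 (0.54 log units; beyond the scatter), seen on the other core. A step of about the same size, a 3.5-fold higher number from compound 3 to compound 4 (0.54 log units; beyond the scatter), is therefore expected from compound 3 to compound 4 in this assay, because compound 3 starts from 0.01 ug/mL and the same change is being made. On that basis compound 4 is estimated at 0.035 ug/mL, with a plausible range from 0.01 ug/mL to 0.12 ug/mL; a number this small may also come back only as a limit of the assay.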

Compound 4, solubility: 0.11 ug/mL
Compound 4: middle estimate off by 3.1-fold (0.50 log units), on the low side; the range from low to high includes it.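

In this assay, putting 4-methylpiperazin-1-yl in place of diethylamino on the core of compound 3 gave an 11-fold higher number from compound 3 to compound 4 (1.04 log units; beyond the scatter) and so moved the number the same way as on the core of compound 1, where the same change gave a 3.5-fold higher number from compound 1 to compound 2 (0.54 log units; beyond the scatter) on the earlier pair. The direction therefore carried over, but the size did not stay the same, and the other change tells the same story: phenyl in place of hydrogen on the nitrogen gave a 3.2-fold lower number from compound 2 to compound 4 (0.50 log units; beyond the scatter) with the 4-methylpiperazin-1-yl group present, against a 10-fold lower number from compound 1 to compound 3 (1.00 log units; beyond the scatter) with diethylamino present. Two cores show only that the direction held in this small set, not that it would hold on a further core or that a step measured on one core gives its size on another, and no measurement at hand explains why the sizes differ.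

The compounds shown leave open how other groups in place of diethylamino, such as morpholin-4-yl or a carboxylic acid, would behave on these two cores. They also leave open what a methyl group or a longer chain would do in place of the added phenyl on the nitrogen.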